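A few compounds are considered here, and "the series" means these few. Any claim that something is new, unique, unknown or untested is made for them only; others in the source may bear on it.

Compound 1 `Cc1c[se]c(N/N=C/c2ccc(Cl)cc2)n1` and compound 2 `Clc1ccc(/C=N/Nc2nc(-c3ccccc3)c[se]2)cc1` both carry chloro on an aromatic carbon; compound 3 `COc1ccc(/C=N/Nc2nc(C)c[se]2)cc1` carries methoxy at that place. In a functional assay on DU-145 cells (Homo sapiens) for cytotoxicity, read by XTT assay, with a stated time of 72 h (a higher number here means a weaker inhibitor, a lower number a stronger inhibitor), compound 1 gives 49400 nM and compound 2 gives 54200 nM, and the step of a 1.1-fold higher number from compound 1 to compound 2 (0.04 log units; within the scatter) stays within the scatter. For compound 3 this assay reports only a limit, > 84900 nM, so compound 3 stands at the limit of > 84900 nM in this assay, at which 1 of the 3 values shown sits. The step of an at least 1.7-fold higher number from compound 1 to compound 3 (0.23 log units; that floor lies within the scatter) is accordingly known only as a floor. Compound 4 `COc1ccc(/C=N/Nc2nc(-c3ccccc3)c[se]2)cc1` differs from compound 3 by phenyl in place of methyl on an aromatic carbon. For the measured compounds named here, the one measured instance of this exchange, a 1.1-fold higher number from compound 1 to compound 2 (0.04 log units; within the scatter), left the number essentially unchanged, so no measured step suggests that compound 4 should move away from the limit at which compound 3 stands. For compound 4 the value expected in this assay is 90000 nM, with a range from 40000 nM to 200000 nM. The expected step that the limit leaves unreadable from compound 3 to compound 4 is estimated as none beyond the scatter, and a limit rather than a number is the likelier outcome.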

Compound 4, half-maximal inhibitory concentration: 50900 nM
The estimate for compound 4 lay 1.8-fold (0.25 log units) above the measured number, and the stated range covers the measured number.
By their numbers in this assay, from the lowest: compounds 1, 4 and 2 (each within the scatter of the next). At a limit, above all of these: compound 3.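

In this assay, phenyl in place of methyl on an aromatic carbon next to the ring nitrogen now yields a number on the methoxy core, where compound 3 had only a limit, and the step is an at least 1.6-fold lower number from compound 3 to compound 4 (0.22 log units; that floor lies within the scatter). Methoxy in place of chloro, earlier known only as a floor, now reads on the phenyl core as a 1.1-fold lower number from compound 2 to compound 4 (0.03 log units; within the scatter), which leaves the two compounds within the scatter of each other. Whether the phenyl exchange acts alike on both cores stays unsettled: the same change on two cores in this assay, a 1.1-fold higher number (0.04 log units; within the scatter) from compound 1 to compound 2 and an at least 1.6-fold lower number (0.22 log units; that floor lies within the scatter) from compound 3 to compound 4; the limit leaves it open whether they differ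

On these data alone, the same holds for the methoxy exchange: the same change on two cores in this assay, an at least 1.7-fold higher number (0.23 log units; that floor lies within the scatter) from compound 1 to compound 3 and a 1.1-fold lower number (0.03 log units; within the scatter) from compound 2 to compound 4; the limit leaves it open whether they differ It also remains open whether an amine or a carboxylic acid at this place, next to the ring nitrogen, would give a step beyond the scatter in this assay.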